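Para methoxy in place of methyl on compound 1

The source may report more compounds than this note shows. Statements on the series, on what has been measured and on what is new or still open speak of the compounds shown alone.

Compound 1 `C#CCSc1nc(Nc2ccc(C)cc2)c2ccncc2n1` holds the second highest number of the three measured in a functional assay on MGC-803 cells (Homo sapiens) for inhibition, read by MTT assay, with a stated time of 72 h (a higher number here means a weaker inhibitor, a lower number a stronger inhibitor), giving 8090 nM. Compound 2 `C#CCSc1nc(Nc2ccccc2Cl)c2ccncc2n1` gives 27600 nM, and compound 3 `C#CCSc1nc(Nc2cccc(OC)c2)c2ccncc2n1` gives 2070 nM. Among the measured compounds shown here, the only single-point step recorded, a 3.4-fold higher number from compound 1 to compound 2 (0.53 log units; beyond the scatter), exchanges the whole aryl group and leaves the methyl untouched. Compound 4 `C#CCSc1nc(Nc2ccc(OC)cc2)c2ccncc2n1` differs from compound 1 by methoxy in place of methyl on an aromatic carbon. For the measured compounds named here, no measured step bears directly on this change; compound 3 also carries a methoxy, though on a different carbon, and its number lies below that of compound 1. A modest step toward a lower number is therefore expected, a 1.6-fold lower number from compound 1 to compound 4 (0.21 log units; within the scatter), with wide uncertainty. Compound 4 is estimated at 5000 nM, within a range of 1500 nM to 16000 nM.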

Compound 4, half-maximal inhibitory concentration: > 80000 nM
Compound 4: a limit, no number; the forecaster's own chance of this, stated with the estimate: 5%; at least 16-fold (1.20 log units) between middle value and limit.
By their numbers in this assay, from the lowest: compound 3; then compound 1; then compound 2. At a limit, above all of these: compound 4.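

Compound 4 reads as a limit in this assay, not as a number: the limit of > 80000 nM in this assay, at which 1 of the 4 values shown sits. At this carbon, para to a large group, methoxy in place of methyl is far from a neutral exchange, with an at least 9.8-fold higher number from compound 1 to compound 4 (0.99 log units; beyond the scatter). A methoxy alone does not bring a high number: compound 3, with methoxy on a different carbon, gives 2070 nM.

With only methyl and methoxy shown on this carbon, whether the oxygen itself carries the loss stays open. Going by these compounds, how a hydroxyl, an amine or an ethyl group would read here is also open.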